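Moving to the 4-methylpyridin-3-yl sulfonyl group

The compounds below may be only part of what the source reports. "The series", "measured", "known", "first", "only" and "open" are said of these compounds alone.

Within the data shown here, in a physicochemical assay for lipophilicity, read by HPLC, at pH 7.4 (on this read-out higher numbers stand for higher lipophilicity and lower numbers for lower lipophilicity), compound 3 (`CNCc1cn(S(=O)(=O)c2ncccc2C)c(-c2cccnc2F)c1F`) reads 0.32, the highest of the three numbers so far. Compound 2 (`CNCc1cc(-c2cccnc2F)n(S(=O)(=O)c2ccsc2)c1`) reads -0.83 and compound 1 (`CNCc1cc(-c2cccnc2F)n(S(=O)(=O)c2cccnc2)c1`) reads -0.85. Both gaps to compound 3 lie beyond the scatter, but compound 3 differs from each of these two in more than one place, so neither gap can be assigned to a single group.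

Compound 4 (`CNCc1cn(S(=O)(=O)c2cnccc2C)c(-c2cccnc2F)c1F`) differs from compound 3 in one place: 4-methylpyridin-3-yl in place of 3-methylpyridin-2-yl on a sulfonyl sulfur. This puts 4-methylpyridin-3-yl in place of 3-methylpyridin-2-yl on a sulfonyl sulfur, and the two compounds have the same atoms, joined differently.

Among the measured compounds shown here, only one measured step bears on this change: a number 0.02 log units higher from compound 1 to compound 2 (within the scatter). It also exchanges one ring for another on a sulfonyl sulfur, and it stays within the scatter. It is a single step on a different core and involves no methylpyridine group, so it is weak support and the range has to stay wide.

In this assay no shift beyond the scatter is expected, and the estimated step is a number 0.07 log units lower from compound 3 to compound 4 (within the scatter). For compound 4 the estimate is 0.25, with an expected range from -0.2 to 0.7.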

Compound 4, distribution coefficient: 0.43
Compound 4: middle estimate off by 0.18 log units, on the low side; low and high end bracket the measured number.
By their numbers in this assay, from the lowest: compounds 1 and 2 (each within the scatter of the next); then compounds 3 and 4 (each within the scatter of the next).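

In this assay, replacing 3-methylpyridin-2-yl with 4-methylpyridin-3-yl on a sulfonyl sulfur gives a number 0.11 log units higher from compound 3 to compound 4 (within the scatter), so this exchange between two groups with the same atoms, joined differently, leaves the two compounds indistinguishable on this read-out. This is the only step here that compares two methylpyridine groups on the core of compound 3, whereas the earlier step, a number 0.02 log units higher from compound 1 to compound 2 (within the scatter), exchanged pyridin-3-yl for thiophen-3-yl on a different core; both single exchanges on the sulfonyl sulfur now stay within the scatter, and no exchange at this position among the compounds shown goes against that. Nothing measured here bears on the reason for the result.

The divide between compounds 1 and 2 on one side and compounds 3 and 4 on the other remains unassigned, with each compound of one pair differing from each of the other in more than one place, so no single group can be credited with it. Also open, as far as these compounds go, is how the read-out would respond on this sulfonyl sulfur to a group outside the methylpyridines on the core of compound 3, such as a plain phenyl ring or a ring carrying a carboxylic acid.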